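Caffeic ester triazoles: halogen swap on the pendant phenyl

A few compounds are considered here, and "the series" means these few. Any claim that something is new, unique, unknown or untested is made for them only; others in the source may bear on it.

Measured compounds in a functional assay on PC-3 cells (Homo sapiens) for antiproliferative activity, read by MTT assay, with a stated time of 72 h; on this read-out higher numbers stand for weaker inhibition and lower numbers for stronger inhibition:
compound 1 `CC(=O)Oc1ccc(/C=C/C(=O)OCCSc2nc(-c3ccc(S(C)(=O)=O)cc3)n(-c3ccc(C(F)(F)F)cc3)n2)cc1OC(C)=O` gives 14500 nM
compound 2 `CS(=O)(=O)c1ccc(-c2nc(SCCOC(=O)/C=C/c3ccc(O)c(O)c3)nn2-c2ccccc2)cc1` gives 14600 nM
compound 3 `CS(=O)(=O)c1ccc(-c2nc(SCCCOC(=O)/C=C/c3ccc(O)c(O)c3)nn2-c2ccc(Br)cc2)cc1` gives 12400 nM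

All three numbers sit close together. Compound 3 has the lowest of the three values, but its nearest neighbour, compound 1, lies within the scatter of it, as does compound 2, so no ranking among the three can be read from these data. Among the compounds with values here, the three compounds differ in more than one place at once, so no single-change step between them is available.

Compound 4 `CS(=O)(=O)c1ccc(-c2nc(SCCCOC(=O)/C=C/c3ccc(O)c(O)c3)nn2-c2ccc(F)cc2)cc1` is the next member. Relative to compound 3 it carries fluoro in place of bromo on an aromatic carbon, that is, fluoro in place of bromo on an aromatic carbon of the phenyl that hangs from the shared core. Within the data shown here, no measured pair isolates this change, so there is no step to lean on.

The expectation for this assay is a step from compound 3 to compound 4 of a 1.0-fold higher number from compound 3 to compound 4 (0.02 log units; within the scatter), i.e. none beyond the scatter in either direction. Compound 4 is accordingly estimated at 13000 nM, with a range from 7000 nM to 25000 nM.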

Compound 4, half-maximal inhibitory concentration: 10100 nM
Beside the measured number, compound 4's estimate is 1.3-fold (0.11 log units) above it, and the stated range covers the measured number.
By their numbers in this assay, from the lowest: compounds 4, 3, 1 and 2 (each within the scatter of the next).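

In this assay, within the data shown here, the change from 4-bromophenyl to 4-fluorophenyl gives a 1.2-fold lower number from compound 3 to compound 4 (0.09 log units; within the scatter) and is the first single-change step available. On an aromatic carbon para to a large group, bromo and fluoro are therefore not told apart by this read-out, so this one exchange of halogens gives no handle on the number. No accompanying measurement bears on this step.

On these data alone, whether a non-halogen group at the same place, such as an amine, a carboxylic acid or a methoxy group, would shift the number beyond the scatter remains open. Also open, as far as these compounds go, is whether a longer chain on the sulfur would do so with either halogen in place.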